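Nitro Group on the Shared Core of Compound 1

The source may report more compounds than this note shows. Statements on the series, on what has been measured and on what is new or still open speak of the compounds shown alone.

Measured so far in an assay on isolated protein for inhibition of ribosomal protein S6 kinase alpha-2 (Homo sapiens), read by fluorescence, with a stated time of 20 min, tested at 10 uM; on this read-out higher numbers stand for more inhibition at the one concentration tested (going by the name of the read-out) and lower numbers for less inhibition:
compound 1, `Cc1ccc(NCN2C(=O)c3ccccc3C2=O)cc1`, gives 54%
compound 2, `CC(C)c1ccc(NCN2C(=O)c3ccccc3C2=O)cc1`, gives 46.5%

Among the compounds with values here, compound 1 has the higher of the two numbers, but the only measured step, a number 7.5 percentage points lower from compound 1 to compound 2 (within the scatter), lies within the scatter, so the two compounds cannot be ranked against each other. That step swaps one group for another on the outer aromatic ring that carries the amine, and it says little about the rest of the molecule.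

Compound 3, `Cc1ccc(NCN2C(=O)c3ccc([N+](=O)[O-])cc3C2=O)cc1`, changes compound 1 in a different place: nitro in place of hydrogen on an aromatic carbon. Within the data shown here, the new group sits on the fused ring system of the shared core, where no measured step has yet touched anything. Among the measured compounds shown here, no comparison among the measured compounds therefore bears directly on this change, and the one step that exists, from compound 1 to compound 2, was itself within the scatter.

With nothing in the data pointing either way, compound 3 is expected to show no step beyond the scatter, a number 4 percentage points lower from compound 1 to compound 3 (within the scatter). The estimate for compound 3 is 50%, with a range from 28% to 72%; the range is wide, since the core has not been varied among the measured compounds.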

Compound 3, a percentage reported as inhibition, at one concentration (the size of the read-out at that concentration, not a potency): 35.7%
Compound 3: middle estimate off by 14.3 percentage points, on the high side; low and high end bracket the measured number.
By their numbers in this assay, from the lowest: compound 3; then compounds 2 and 1 (each within the scatter of the next).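

Until now only the outer aromatic ring had been varied, and that change stayed within the scatter, so nothing showed whether the read-out responds to changes in the shared core. In this assay, within the data shown here, placing nitro on an aromatic carbon of the core gives a number 18.3 percentage points lower from compound 1 to compound 3 (beyond the scatter) and so provides the first step in this small set that can be read as a real difference. The core is therefore not a silent part of these molecules, although the modest step leaves compound 3 with 35.7% at the one concentration tested, so the added group lowers the inhibition without abolishing it. Nothing measured here explains why the number falls at this position.

The compounds shown leave open whether the lower number belongs to nitro itself or to any group on this aromatic carbon, a question that an amine or a carboxylic acid at the same place could help to settle. They also leave open whether nitro would produce a similar step on the core of compound 2, which carries isopropyl in place of methyl.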